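The source may report more compounds than this note shows. Statements on the series, on what has been measured and on what is new or still open speak of the compounds shown alone.

Measured compounds:
compound 1 `Nc1ccccc1NC(=O)/C=C/c1ccc(Cn2cnc3c(Nc4cccc(OC(F)(F)F)c4)nc(Cl)nc32)cc1`, which in a functional assay on HCT-116 cells (Homo sapiens) for antiproliferative activity, read by CCK-8 assay, with a stated time of 72 h, tested at 2 uM (a lower number here means a weaker effect, a higher number a stronger effect of the compound at the concentration tested), gives 2.8%
compound 2 `CCCCn1cnc2c(Nc3ccccc3)nc(NCOCc3ccc(/C=C/C(=O)Nc4ccccc4N)cc3)nc21`, which in this assay gives 6.58%
compound 3 `Nc1ccccc1NC(=O)c1ccc(Cn2cnc3c(Nc4cccc(OC(F)(F)F)c4)nc(Cl)nc32)cc1`, which in this assay gives 1.6%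

Compound 1 and compound 3 differ by one change, ((2-aminophenyl)carbamoyl in place of 2-((2-aminophenyl)carbamoyl)ethenyl on an aromatic carbon), and the step in this assay is a number 1.2 percentage points lower from compound 1 to compound 3 (within the scatter). The difference between the core of compound 1 and the core of compound 2 is not broken down here; their two values lie close together.

Compound 4 `CCCCn1cnc2c(Nc3ccccc3)nc(NCOCc3ccc(C(=O)Nc4ccccc4N)cc3)nc21` is not yet measured. It arises from compound 2 by the same change, ((2-aminophenyl)carbamoyl in place of 2-((2-aminophenyl)carbamoyl)ethenyl on an aromatic carbon), at the same kind of position. Because the measured step of a number 1.2 percentage points lower from compound 1 to compound 3 (within the scatter) was small, the step from compound 2 to compound 4 in this assay is expected to be small as well, about a number 1.2 percentage points lower from compound 2 to compound 4 (within the scatter). Compound 4 is therefore estimated at 5.4%, most likely between 0% and 14%.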

Compound 4, a percentage reported as inhibition, at one concentration (the size of the read-out at that concentration, not a potency): 72.9%
Beside the measured number, compound 4's estimate is 67.5 percentage points below it; the measured number lies above the stated range.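

In this assay, putting (2-aminophenyl)carbamoyl in place of 2-((2-aminophenyl)carbamoyl)ethenyl gives a number 66.3 percentage points higher from compound 2 to compound 4 (beyond the scatter). For the compounds shown here, the change therefore does not carry over from one core to the other with the same size, and its effect here depends on the core that bears it: the same change on two cores in this assay, a number 1.2 percentage points lower (within the scatter) from compound 1 to compound 3 and a number 66.3 percentage points higher (beyond the scatter) from compound 2 to compound 4, 67.5 percentage points apart, beyond the scatter of two such steps With only one pair on each core, this does not show which difference between the cores matters, nor how the change would behave on any third core.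

The compounds shown leave open whether a butyl chain on the core of compound 1 would bring out the same large step. They also leave open how a hydroxamic acid in place of the 2-aminophenyl amide would behave on either core.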